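The compounds below may be only part of what the source reports. "The series", "measured", "known", "first", "only" and "open" are said of these compounds alone.

In a functional assay on HepG2 cells (Homo sapiens) for cytotoxicity, read by MTT assay, with a stated time of 72 h (on this read-out lower numbers stand for stronger inhibition and higher numbers for weaker inhibition), compound 1 `O=C(N/N=C/c1cccc(Br)c1)Nc1cc2c(Nc3ccc(F)c(Cl)c3)ncnc2cc1O[C@H]1CCOC1` gives 32300 nM, the highest of the three numbers recorded, though every gap to the others lies within the scatter. Compound 2 `COc1ccc(/C=N/NC(=O)Nc2cc3c(Nc4ccc(F)c(Cl)c4)ncnc3cc2O[C@H]2CCOC2)cc1` gives 28800 nM in this assay, and compound 3 `COc1cc(/C=N/NC(=O)Nc2cc3c(Nc4ccc(F)c(Cl)c4)ncnc3cc2O[C@H]2CCOC2)cc(OC)c1OC` gives 31200 nM. The three steps among them, a 1.1-fold lower number from compound 1 to compound 2 (0.05 log units; within the scatter), a 1.0-fold lower number from compound 1 to compound 3 (0.02 log units; within the scatter) and a 1.1-fold higher number from compound 2 to compound 3 (0.03 log units; within the scatter), all stay within the scatter, so swapping the aryl group on the carbon with a double bond to nitrogen has so far left the read-out unchanged.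

Compound 4 `O=C(N/N=C/c1cc(Br)c(O)c(Br)c1)Nc1cc2c(Nc3ccc(F)c(Cl)c3)ncnc2cc1O[C@H]1CCOC1` is the unmeasured member. It differs from compound 1 by 3,5-dibromo-4-hydroxyphenyl in place of 3-bromophenyl on a carbon with a double bond to nitrogen. For the measured compounds named here, the steps that bear on this are those from compound 1 to compounds 2 and 3, both within the scatter, and neither covered a hydroxyl or two bromines on that ring. Going by the values given here, with no step exceeding the scatter, the expectation for compound 4 is a number close to that of compound 1, with a step of a 1.1-fold lower number from compound 1 to compound 4 (0.03 log units; within the scatter) expected in this assay. Compound 4 is therefore estimated at 30000 nM, within a range of 14000 nM to 65000 nM.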

Compound 4, half-maximal inhibitory concentration: 2740 nM
Beside the measured number, compound 4's estimate is 11-fold (1.04 log units) above it, and the stated range ends above it.
By their numbers in this assay, from the lowest: compound 4; then compounds 2, 3 and 1 (each within the scatter of the next).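

In this assay, the aryl group on the carbon with a double bond to nitrogen does move the read-out: 3,5-dibromo-4-hydroxyphenyl gives large steps beyond the scatter (a 12-fold lower number from compound 1 to compound 4 (1.07 log units; beyond the scatter); an 11-fold lower number from compound 2 to compound 4 (1.02 log units; beyond the scatter); an 11-fold lower number from compound 3 to compound 4 (1.06 log units; beyond the scatter)), whereas the swaps among compound 1, compound 2 and compound 3 all stayed within it. Relative to 3-bromophenyl, the entering group adds a hydroxyl and a further bromine together, so these compounds do not separate the share of either. Nothing available gives a cause for these steps.

Going by these compounds, it remains open whether a phenyl group carrying only the hydroxyl or only the two bromines would reach the number of compound 4. Also open, on these data alone, is how an amine or a carboxylic acid in place of that hydroxyl would read.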